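Swapping the bromophenyl of compound 1 for a difluorophenyl

This account rests on a few compounds, and the source may have more. Where it says the series, first, only, none or still open, it means among the compounds named here.

Going by the values given here, compound 1, with the structure `O=C(COc1ccc(C(=O)/C=C/c2cccc(Br)c2)cc1)N[C@H]1CCOC1=O`, is the one compound here whose activity was read as a number: in a functional assay on MCF7 cells (Homo sapiens) for antiproliferative activity, read by MTT assay, with a stated time of 72 h (a higher number here means a weaker inhibitor, a lower number a stronger inhibitor), compound 1 gives 28300 nM. Compound 2 `CC(C)c1ccc(NCC(=O)N[C@H]2CCOC2=O)cc1` reaches only (the limit of > 64000 nM in this assay, at which 2 of the 3 values shown sit), so in this assay compound 2 shows > 64000 nM, a limit rather than a number. Compound 3 `O=C(CNc1ccc(Cl)cc1)N[C@H]1CCOC1=O` likewise stops at a limit, giving > 64000 nM in this assay. Among the compounds with values here, the one measured step, a step that the two limits leave unreadable from compound 2 to compound 3, cannot be read because both ends are limits, and it concerns a different part of the molecule from the change that leads to compound 4.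

Compound 4 has the structure `O=C(COc1ccc(C(=O)/C=C/c2ccc(F)c(F)c2)cc1)N[C@H]1CCOC1=O`. It differs from compound 1 by 3,4-difluorophenyl in place of 3-bromophenyl on a double-bonded chain carbon bound to a double-bonded chain carbon: a halogen-bearing ring on the double-bonded chain carbon is replaced by another halogen-bearing ring of the same kind, with fluorine in place of bromine and one more halogen added. Within the data shown here, no measured step speaks to this exchange, so there is no ground to expect a shift beyond the scatter in this assay. Compound 4 is therefore estimated to sit close to compound 1, at 26000 nM, within 8000 nM to 80000 nM, which corresponds to an expected step of a 1.1-fold lower number from compound 1 to compound 4 (0.04 log units; within the scatter).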

Compound 4, half-maximal inhibitory concentration: > 64000 nM
Compound 4 ended at the assay's limit (the forecaster's own chance of this, stated with the estimate: 25%); middle value at least 2.4-fold (0.39 log units) away from the limit.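

In this assay, the ring on the double-bonded chain carbon proves not to be a free exchange: 3,4-difluorophenyl in place of 3-bromophenyl gives an at least 2.2-fold higher number from compound 1 to compound 4 (0.35 log units; beyond the scatter), so this small swap between two halogen-bearing rings moves activity beyond the scatter. This is the only step among the compounds shown that can be read, as the step between the two earlier limits cannot, and it is the first sign that the halogens on this ring matter to the antiproliferative effect. Compound 4 gave a limit and not a number, so the true size of the step stays unknown, and compound 1 remains the only compound with a readable value: the limit of > 64000 nM in this assay, at which 3 of the 4 values shown sit.

The compounds shown do not separate the loss of bromine from the gain of fluorine, and a 3-fluorophenyl or a 3-chlorophenyl at this place would tell the two apart. Also open, as far as these compounds go, is whether a ring of another kind on this carbon, such as a 3-methoxyphenyl or an aminophenyl, would give a lower number than compound 1 does.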